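Removing the ester of compound 3: from propyl to hydrogen

A few compounds are considered here, and "the series" means these few. Any claim that something is new, unique, unknown or untested is made for them only; others in the source may bear on it.

Three measured compounds share one core and differ only in the group attached to an oxygen next to a carbonyl group. Compound 1 `NCc1ccc(C(=O)Nc2ccncc2F)cc1-c1cccc(C(=O)Oc2ccccc2)c1` gives 6.2 nM in an assay on isolated protein for inhibition of Rho-associated protein kinase 2 (Homo sapiens), read by radiometric assay; a lower number here means a stronger inhibitor, a higher number a weaker inhibitor. Compound 2 `NCc1ccc(C(=O)Nc2ccncc2F)cc1-c1cccc(C(=O)OCC2CCCCO2)c1` gives 12 nM, and compound 3 `CCCOC(=O)c1cccc(-c2cc(C(=O)Nc3ccncc3F)ccc2CN)c1` gives 5.1 nM. Compound 3 has the lowest number of the three; the step of a 1.2-fold lower number from compound 1 to compound 3 (0.08 log units; within the scatter) is within the scatter, while the step of a 2.4-fold lower number from compound 2 to compound 3 (0.37 log units; beyond the scatter) is a modest one beyond the scatter. The exchange a 1.9-fold higher number from compound 1 to compound 2 (0.29 log units; within the scatter) is likewise within the scatter.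

Compound 4 `NCc1ccc(C(=O)Nc2ccncc2F)cc1-c1cccc(C(=O)O)c1` is the next step: hydrogen in place of propyl on an oxygen next to a carbonyl group. All three measured steps bear on this place, and each was small, because a 1.2-fold lower number from compound 1 to compound 3 (0.08 log units; within the scatter) and a 1.9-fold higher number from compound 1 to compound 2 (0.29 log units; within the scatter) stayed within the scatter and a 2.4-fold lower number from compound 2 to compound 3 (0.37 log units; beyond the scatter) was only modest. Among the compounds with values here, none of them, however, removed the ester entirely, so no measured step matches the change to hydrogen directly. The expectation is therefore a small to modest rise in the number, a 3.9-fold higher number from compound 3 to compound 4 (0.59 log units; beyond the scatter), with a wide range to cover the missing precedent. Compound 4 is estimated at 20 nM, between 5 nM and 80 nM.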

Compound 4, half-maximal inhibitory concentration: 55 nM
The estimate for compound 4 lay 2.8-fold (0.44 log units) below the measured number; measured number inside the range.
By their numbers in this assay, from the lowest: compounds 3, 1 and 2 (each within the scatter of the next, the first and the last beyond it); then compound 4.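

In this assay, the phenyl, propyl and (oxan-2-yl)methyl groups differ little from one another, but replacing any of them with hydrogen produces a clear change: the propyl exchange gives an 11-fold higher number from compound 3 to compound 4 (1.03 log units; beyond the scatter), the phenyl exchange gives an 8.9-fold higher number from compound 1 to compound 4 (0.95 log units; beyond the scatter), and the (oxan-2-yl)methyl exchange gives a 4.6-fold higher number from compound 2 to compound 4 (0.66 log units; beyond the scatter). All three steps point the same way and lie beyond the scatter, so this position, which seemed to accept very different ester groups, is sensitive to going from an ester to the free carboxy group. The earlier compounds could not show this, since each of them keeps a carbon group on that oxygen, and nothing measured here explains the rise.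

On these data alone, what remains open is how little carbon on that oxygen is enough to hold the low numbers of the esters, for example whether a methyl ester would sit with compounds 1, 2 and 3 or with compound 4. As far as these compounds go, it is also open how a primary amide or a tetrazole in place of the carboxy group would read in this assay.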